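Swapping the aryl ring on a shared oxazole-piperidine core

The compounds below may be only part of what the source reports. "The series", "measured", "known", "first", "only" and "open" are said of these compounds alone.

Compound 1, `Cc1oc(-c2c(Br)cccc2Br)nc1CN1CCC(C(=O)NCCCN2C[C@H](C)C[C@H](C)C2)CC1`: 62.4 ug/mL
Compound 2, `CCCN(CCC)CCNC(=O)C1CCN(Cc2nc(-c3ccccc3C)oc2C)CC1`: > 65 ug/mL

Two measured compounds open this account. For the measured compounds named here, in a physicochemical assay for solubility, in phosphate buffer, measured as kinetic solubility, at pH 7.4 (on this read-out higher numbers stand for higher solubility and lower numbers for lower solubility), compound 1 gives 62.4 ug/mL, the only plain number in the set. Compound 2 in this assay reaches > 65 ug/mL, which is a limit of the assay rather than a number; the limit of > 65 ug/mL in this assay, at which 1 of the 2 values shown sits, states where that boundary sits. Going by the values given here, no step between the two measured compounds is given, since they differ in more than one place, so only their two values stand side by side.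

The piece now turns to compound 3, `Cc1cc(C)cc(-c2nc(CN3CCC(C(=O)NCCCN4C[C@H](C)C[C@H](C)C4)CC3)c(C)o2)c1`, which has not yet been measured in this assay. It differs from compound 1 by 3,5-dimethylphenyl in place of 2,6-dibromophenyl on an aromatic carbon. Nothing measured here ties this exchange to a change in solubility, so the expectation rests on the closeness of compound 1 to the boundary of the assay. The step from compound 1 to compound 3 is expected to be small, upward if anything, and to remain within the usual scatter, as a 1.0-fold higher number from compound 1 to compound 3 (0.02 log units; within the scatter) expresses. Compound 3 is thus expected to give about 65 ug/mL in this assay, with a range from 32 ug/mL to 130 ug/mL.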

Compound 3, solubility: > 71 ug/mL
Compound 3: no number, only a limit (the forecaster's own chance of this, stated with the estimate: 55%); middle value at least 1.0-fold (0.03 log units) from the limit.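

Compound 3 does not give a number but a limit of the assay: the limit of > 71 ug/mL in this assay, at which 1 of the 3 values shown sits. For the compounds shown here, the exchange of 2,6-dibromophenyl for 3,5-dimethylphenyl on an aromatic carbon, next to the ring nitrogen and the ring oxygen, gives an at least 1.1-fold higher number from compound 1 to compound 3 (0.05 log units; that floor lies within the scatter), the first step at this position that the account can read, and it fixes only a floor, not a size. What it adds to the earlier compounds is narrow: with the side chain of compound 1 held constant, this position takes an aryl group with no bromine and the same count of heavy atoms, and this assay shows no fall from compound 1 to compound 3, though the data give no reason for this.

From the compounds shown here alone, how far compound 3 really lies from compound 1 stays open, since a limit cannot turn that floor into a measured difference. Also open, going by these compounds, is how this assay would read with a single bromine, a methoxy group or a carboxylic acid on this aryl ring, or with a pyridine ring in its place.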